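Swapping hydroxymethyl for pyrrolidine on the chain

This account rests on a few compounds, and the source may have more. Where it says the series, first, only, none or still open, it means among the compounds named here.

Compound 1, `Cn1ncc(Cl)c1-c1cc(C(=O)N[C@@H]2CN[C@H](CCCO)C[C@H]2c2ccc(Cl)c(Cl)c2)oc1Cl`, in an assay for inhibition of RAC-alpha serine/threonine-protein kinase (Homo sapiens), read by HTRF, with a stated time of 1 h; on this read-out higher numbers stand for weaker inhibition and lower numbers for stronger inhibition: 2.56 nM
Compound 2, `CC(=O)NCC[C@@H]1C[C@@H](c2ccc(F)c(F)c2)[C@H](NC(=O)c2cc(-c3c(Cl)cnn3C)c(Cl)o2)CN1`, in this assay: 2.49 nM
Compound 3, `CC(=O)OCC[C@@H]1C[C@@H](c2ccc(F)c(F)c2)[C@H](NC(=O)c2cc(-c3c(Cl)cnn3C)c(Cl)o2)CN1`, in this assay: 3.4 nM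

Compound 1 gives the second highest of the three numbers. Its nearest neighbour is compound 2 and its furthest is compound 3, and both gaps lie within the scatter, so on these data the three compounds cannot be told apart.

Compound 4, `Cn1ncc(Cl)c1-c1cc(C(=O)N[C@@H]2CN[C@H](CCN3CCCC3)C[C@H]2c2ccc(Cl)c(Cl)c2)oc1Cl`, differs from compound 1 in one place: pyrrolidin-1-yl in place of hydroxymethyl on a saturated chain carbon, two bonds along the chain from a saturated ring carbon. Within the data shown here, no measured pair shows this exchange. Among the measured compounds shown here, the only measured step, a 1.4-fold higher number from compound 2 to compound 3 (0.14 log units; within the scatter), alters a different group at the same place on the chain and stays within the scatter. For the measured compounds named here, it shows only that one exchange at the end of that chain has passed without a shift in the number, and it says nothing directly about a ring entering there.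

On that thin footing the expectation for compound 4 is a step no larger than the scatter, a 1.0-fold lower number from compound 1 to compound 4 (0.01 log units; within the scatter). Compound 4 is therefore estimated at 2.5 nM, expected to fall between 0.8 nM and 8 nM. Going by the values given here, no measured step covers this exchange, so the range is set wide.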

Compound 4, half-maximal inhibitory concentration: 6.41 nM
Compound 4: the middle estimate sits 2.6-fold (0.41 log units) below what was measured, and the stated range covers the measured number.
By their numbers in this assay, from the lowest: compounds 2, 1, 3 and 4 (each within the scatter of the next, the first and the last beyond it).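

In this assay, among these compounds, the exchange of hydroxymethyl for pyrrolidin-1-yl gives a 2.5-fold higher number from compound 1 to compound 4 (0.40 log units; beyond the scatter), the first step at the end of this chain to go beyond the scatter. The position therefore does respond to what is placed there, which the acetoxy-for-acetamido exchange, with a 1.4-fold higher number from compound 2 to compound 3 (0.14 log units; within the scatter), could not show, yet a larger group carrying a ring costs only a modest step and does not abolish inhibition. Nothing available explains why the number rises with this exchange.

This single step changes several things at once: a ring enters, a nitrogen replaces the oxygen, and the hydrogen-bond donor of the hydroxymethyl is lost, so the compounds shown cannot say which of these matters. Going by these compounds, it also remains open whether an open-chain dimethylamino group, a six-membered piperidine ring or a carboxylic acid at the same place on the chain would give a number closer to that of compound 1 or to that of compound 4.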